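Amino in Place of Methoxy at a Cytotoxicity Limit

This account rests on a few compounds, and the source may have more. Where it says the series, first, only, none or still open, it means among the compounds named here.

Compound 1 `COc1ccc(-c2cc3ccccc3c(-c3cccc(OC)c3)n2)cc1` gives > 50000 nM in an ADME assay on MCF-10A cells (Homo sapiens) for cytotoxicity, read by CCK-8 assay and cell counting, with a stated time of 72 h (on this read-out lower numbers stand for stronger inhibition and higher numbers for weaker inhibition), a limit.
Compound 2 `COc1cc(OC)cc(-c2cc3ccccc3c(-c3cccc(O)c3)n2)c1` gives 6770 nM.
Compound 3 `COc1cc(OC)cc(-c2cc3ccccc3c(-c3cccc(OC)c3)n2)c1` gives > 50000 nM, also a limit.

Compound 3 therefore sits at the limit of > 50000 nM in this assay, at which 2 of the 3 values shown sit, so its number tells only that inhibition is weak there. Compound 4 `COc1cc(OC)cc(-c2cc3ccccc3c(-c3cccc(N)c3)n2)c1` differs from it by amino in place of methoxy on an aromatic carbon. Among the compounds with values here, one measured step touches the same position: an at least 7.3-fold higher number from compound 2 to compound 3 (0.86 log units; beyond the scatter), where a hydrogen on the oxygen gave a measurable number and its methyl took the compound to the limit. Since the incoming amino likewise brings a hydrogen-bond donor, compound 4 is expected to give a lower number, an estimated step of an at least 3.3-fold lower number from compound 3 to compound 4 (0.52 log units; beyond the scatter). The estimate for compound 4 is 15000 nM, between 4000 nM and 50000 nM.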

Compound 4, half-maximal inhibitory concentration: > 50000 nM
Compound 4: no number, only a limit (the forecaster's own chance of this, stated with the estimate: 40%); middle value at least 3.3-fold (0.52 log units) away from the limit.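

Compound 4 sits at a limit, as compound 3 does, so the step between them cannot be read: the limit of > 50000 nM in this assay, at which 3 of the 4 values shown sit.

Amino in place of hydroxy gives an at least 7.3-fold higher number from compound 2 to compound 4 (0.86 log units; beyond the scatter). So at this place on the ring, the hydrogen-bond donor that amino brings is not enough to give a measurable number, and among the groups shown there, only the hydroxy of compound 2 does so.

On these data alone, whether a carboxylic acid or a hydroxymethyl there would also give a measurable number stays open. So does how weak compound 3 and compound 4 really are.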